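One nitrogen substituent changes: compound 1 to compound 4

The source may hold more compounds than are shown below. What is called first, only, known or untested is meant among the compounds shown, and "the series" means these compounds.

Measured so far in a functional assay on OVCAR-3 cells (Homo sapiens) for antiproliferative activity, read by MTT assay, with a stated time of 24 h; a lower number here means a stronger inhibitor, a higher number a weaker inhibitor
compound 1 `O=C(NNc1ccccc1F)c1cccc(NS(=O)(=O)c2cnc(O)nc2O)c1` gives 17000 nM
compound 2 `Cc1ccc(C(=O)NNC(=O)c2ccc(NS(=O)(=O)c3cnc(O)nc3O)cc2)cc1` gives > 20000 nM (a limit)
compound 3 `O=C(NNC(=O)c1ccc(NS(=O)(=O)c2cnc(O)nc2O)cc1)c1ccc(F)cc1` gives > 20000 nM (a limit)

Among the measured compounds shown here, compound 1 holds the only true number here, 17000 nM, in this assay. The rest is the limit of > 20000 nM in this assay, at which 2 of the 3 values shown sit, for compound 2 and compound 3, which is a limit and not a number. How far compound 1 lies from those two therefore cannot be read.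

Compound 4 `O=C(NNC(=O)c1cccc(NS(=O)(=O)c2cnc(O)nc2O)c1)c1cccc(Cl)c1` has not yet been measured. It differs from compound 1 as follows: (3-chlorophenyl)carbonyl in place of 2-fluorophenyl on an amine nitrogen.

For the measured compounds named here, the one measured step, a step that the two limits leave unreadable from compound 2 to compound 3, has no readable size, so it offers no direct guide. The nearest hint comes from the new carbonyl group, although the cores are not identical. Compound 2 also carries an aromatic group joined through a carbonyl on that nitrogen and gives > 20000 nM, which is a limit. Compound 3 carries such a group too and gives > 20000 nM, again a limit.

In this assay no step beyond the scatter is therefore expected, and any drift would be towards a weaker inhibitor. The expected change is a 1.3-fold higher number from compound 1 to compound 4 (0.11 log units; within the scatter) and it is only an estimate. For compound 4 the estimated value is 22000 nM, with an expected range from 12000 nM to 45000 nM, and the assay may well report only a limit.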

Compound 4, half-maximal inhibitory concentration: 13500 nM
Compound 4: the middle estimate sits 1.6-fold (0.21 log units) above what was measured, and the stated range covers the measured number.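

In this assay, putting (3-chlorophenyl)carbonyl in place of 2-fluorophenyl on this amine nitrogen gives a 1.3-fold lower number from compound 1 to compound 4 (0.10 log units; within the scatter), so the two groups cannot be told apart in this read-out. Among the compounds shown here, compound 2 and compound 3, which also carry an aromatic group joined through a carbonyl on that nitrogen, give only a limit and not a number, so no step involving them can be read: the limit of > 20000 nM in this assay, at which 2 of the 4 values shown sit. Compound 4 now supplies a true number for a group joined through a carbonyl at this place, and it shows that this swap, large as it is in atoms, leaves the result within the scatter of compound 1.

Going by these compounds, the change replaces the halogen, its place on the ring and the link to the nitrogen all at once, so the share of each remains unknown. On these data alone, it also remains open whether a quite different group on this nitrogen, such as a plain acetyl, or an amine or a carboxylic acid on the aromatic ring, would move the number beyond the scatter.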